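The source may hold more compounds than are shown below. What is called first, only, known or untested is meant among the compounds shown, and "the series" means these compounds.

In a functional assay on HepG2 cells (Homo sapiens) for inhibition, read by MTT assay, with a stated time of 24 h (a lower number here means a stronger inhibitor of growth, a higher number a weaker inhibitor of growth), compound 1 `Cn1cc(-c2nc3ccccc3n2C(=O)c2ccccc2)c2ccccc21` gives 42300 nM, compound 2 `COc1ccc(C(=O)n2c(-c3cn(C)c4ccccc34)nc3ccccc32)cc1` gives 15200 nM and compound 3 `COc1ccc(C(=O)n2c(-c3cn(C)c4ccccc34)nc3ccccc32)cc1OC` gives 8400 nM. Compound 2 therefore stands clearly apart from compound 1 but within the scatter of compound 3. Compound 4 `COc1ccc(C(=O)n2c(-c3cn(C)c4ccc(OC)cc34)nc3ccccc32)cc1` differs from compound 2 in one place: methoxy in place of hydrogen on an aromatic carbon. Methoxy replaces hydrogen on an aromatic carbon of a six-membered aromatic ring of carbon only, part of a fused or bridged system of two rings. Two measured steps add methoxy elsewhere on the molecule: a 2.8-fold lower number from compound 1 to compound 2 (0.44 log units; beyond the scatter), and a 1.8-fold lower number from compound 2 to compound 3 (0.26 log units; within the scatter). Neither tests this ring, so only a modest change in the same direction is expected in this assay, and it may stay within the scatter. The expected step is a 1.6-fold lower number from compound 2 to compound 4 (0.20 log units; within the scatter). Compound 4 is estimated at 9500 nM, with an expected range of 3500 nM to 22000 nM.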

Compound 4, concentration for 50% growth inhibition: 12800 nM
Beside the measured number, compound 4's estimate is 1.3-fold (0.13 log units) below it; the measured number falls inside the stated range.
By their numbers in this assay, from the lowest: compounds 3, 4 and 2 (each within the scatter of the next); then compound 1.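

In this assay, methoxy on this six-membered ring of the fused system gives a 1.2-fold lower number from compound 2 to compound 4 (0.07 log units; within the scatter), so at this position the group cannot be told apart from hydrogen. Methoxy elsewhere on the molecule gave a step beyond the scatter in a 2.8-fold lower number from compound 1 to compound 2 (0.44 log units; beyond the scatter), so the same change does not read the same at every place. Nothing available here explains this difference.

From the compounds shown here alone, whether an amine, a carboxylic acid or a longer chain such as ethoxy would shift the number at this position stays open. So does whether methoxy on the other carbons of this ring would behave alike.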